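This account rests on a few compounds, and the source may have more. Where it says the series, first, only, none or still open, it means among the compounds named here.

Compound 1, `Oc1cccc(-c2cc(-c3ccco3)cc(-c3ccccc3O)n2)c1`, gives 820 nM in a functional assay on T47D cells (Homo sapiens) for cytotoxicity, read by CCK-8 assay; a higher number here means a weaker inhibitor, a lower number a stronger inhibitor.
Compound 2, `Oc1ccc(-c2cc(-c3ccco3)cc(-c3cccc(O)c3)n2)cc1`, gives 1280 nM in this assay.
Compound 3, `Oc1ccc(-c2cc(-c3ccco3)cc(-c3ccc(O)cc3)n2)cc1`, gives 21100 nM in this assay.

Among these three numbers compound 2 stands second highest. Its nearest neighbour is compound 1: a 1.6-fold higher number from compound 1 to compound 2 (0.19 log units; within the scatter). Its furthest neighbour is compound 3: a 16-fold higher number from compound 2 to compound 3 (1.22 log units; beyond the scatter).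

Compound 4, `Oc1ccc(-c2cc(-c3cccnc3)cc(-c3cccc(O)c3)n2)cc1`, differs from compound 2 in one place: pyridin-3-yl in place of furan-2-yl on an aromatic carbon. Both measured steps swap the position of a hydroxyl group on one of the hydroxyphenyl rings; neither touches the furan-2-yl group that is exchanged here. For the measured compounds named here, no measured step therefore bears directly on this change, and there is no basis in the data for expecting a step in this assay in either direction beyond the scatter. Compound 4 is therefore estimated at 1500 nM in this assay, with a range of 400 nM to 6000 nM. That estimate means an expected step of a 1.2-fold higher number from compound 2 to compound 4 (0.07 log units; within the scatter). The range is kept deliberately wide: nothing measured addresses this exchange.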

Compound 4, half-maximal inhibitory concentration: > 50000 nM
Compound 4: a limit, no number; the forecaster's own chance of this, stated with the estimate: 5%; at least 33-fold (1.52 log units) between middle value and limit.
By their numbers in this assay, from the lowest: compounds 1 and 2 (each within the scatter of the next); then compound 3. At a limit, above all of these: compound 4.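

The earlier steps shown here only moved a hydroxyl group on the hydroxyphenyl rings, so they said nothing about the group opposite the ring nitrogen. Here, in this assay, pyridin-3-yl in place of furan-2-yl gives an at least 39-fold higher number from compound 2 to compound 4 (1.59 log units; beyond the scatter), which shows that the result at this position can depend strongly on the ring placed there. The value of compound 4 is a limit of the assay and not a number: the limit of > 50000 nM in this assay, at which 1 of the 4 values shown sits.

This exchange alters the ring size and the hetero atom together, so the compounds shown cannot separate one from the other. On these data alone, how a thiophen-2-yl, a plain phenyl or a pyridin-4-yl group would behave at this place remains open.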